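From 4-fluorophenyl to 2,4-difluorophenyl in compound 4

A few compounds are considered here, and "the series" means these few. Any claim that something is new, unique, unknown or untested is made for them only; others in the source may bear on it.

Three compounds with a shared core have numbers in a functional assay on MCF7 cells (Homo sapiens) for antiproliferative activity, read by MTT assay, with a stated time of 72 h; a lower number here means a stronger inhibitor, a higher number a weaker inhibitor. Compound 1 `Cc1ccc(N2CCN(C(=S)SCc3ccc4nc(N)nc(N)c4c3)CC2)c(C)c1` gives 3120 nM, compound 2 `Nc1nc(N)c2cc(CSC(=S)N3CCN(c4ccccc4Cl)CC3)ccc2n1` gives 3190 nM and compound 3 `Nc1nc(N)c2cc(CSC(=S)N3CCN(c4ccc(F)cc4)CC3)ccc2n1` gives 1920 nM. Compound 3 cannot be told apart from the other two, as the data show a 1.6-fold lower number from compound 1 to compound 3 (0.21 log units; within the scatter) and a 1.7-fold lower number from compound 2 to compound 3 (0.22 log units; within the scatter).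

Compound 4 `Nc1nc(N)c2cc(CSC(=S)N3CCN(c4ccc(F)cc4F)CC3)ccc2n1` differs from compound 3 in one place, (fluoro in place of hydrogen on an aromatic carbon). This is fluoro in place of hydrogen on an aromatic carbon, ortho to a large group and meta to a fluoro group, so 4-fluorophenyl becomes 2,4-difluorophenyl.

Among the compounds with values here, no measured step makes exactly this change. The closest evidence comes from the exchanges of one substituted phenyl for another on the amine nitrogen in a ring, which include a 1.0-fold higher number from compound 1 to compound 2 (0.01 log units; within the scatter) alongside the two steps above. All three stay within the scatter, so no step beyond the scatter is expected in this assay, and no direction is favoured. The estimate amounts to an expected 1.2-fold higher number from compound 3 to compound 4 (0.08 log units; within the scatter). Compound 4 is estimated at 2300 nM, with an expected range from 1200 nM to 4400 nM.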

Compound 4, half-maximal inhibitory concentration: 3670 nM
For compound 4 the middle estimate is 1.6-fold (0.20 log units) below the measured one; low and high end bracket the measured number.
By their numbers in this assay, from the lowest: compounds 3, 1, 2 and 4 (each within the scatter of the next).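

In this assay, within the data shown here, fluoro in place of hydrogen on an aromatic carbon, ortho to a large group and meta to a fluoro group, gives a 1.9-fold higher number from compound 3 to compound 4 (0.28 log units; within the scatter) and is the first measured step to change only this position, so the data show that this position takes a fluoro group without a shift that can be told from the scatter. The 2,4-difluorophenyl group also cannot be told apart from the other two groups, with a 1.2-fold higher number from compound 2 to compound 4 (0.06 log units; within the scatter) and a 1.2-fold higher number from compound 1 to compound 4 (0.07 log units; within the scatter) among the steps, so all four substituted phenyl groups shown fall within the scatter of their neighbours in this assay. Nothing measured alongside these numbers bears on the result.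

The phenyl rings shown carry only fluoro, chloro and methyl groups, so it stays open what a methoxy group, a nitrile or a carboxylic acid would do at this position. Also open, from the compounds shown here alone, is whether a phenyl with a single fluoro group at this position, without the fluoro group of compound 3, would fall in the same range.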